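Changing the aryl group on the sulfonyl sulfur

The source may hold more compounds than are shown below. What is called first, only, known or untested is meant among the compounds shown, and "the series" means these compounds.

Measured so far:
Compound 1 `Cc1cc(Nc2ccc(F)cc2)nc(Nc2ccc(NS(=O)(=O)c3ccc(C(F)(F)F)cc3)cc2)n1`, in an assay on isolated protein for inhibition of extracellular serine/threonine protein kinase FAM20C (Homo sapiens), read by malachite green, tested at 10 uM, in the presence of a further agent that is not named here (on this read-out higher numbers stand for more inhibition at the one concentration tested (going by the name of the read-out) and lower numbers for less inhibition), compound 1 gives 24%.
Compound 2 `Cc1cc(Nc2ccc(F)cc2)nc(Nc2ccc(NS(=O)(=O)c3ccccc3OC(F)(F)F)cc2)n1`, compound 2 gives 23%.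

On the numbers shown, compound 2 sits beside compound 1 rather than apart from it: a number 1 percentage points lower from compound 1 to compound 2 (within the scatter). Compound 3 `COc1cc(C)cc(Cl)c1S(=O)(=O)Nc1ccc(Nc2nc(C)cc(Nc3ccc(F)cc3)n2)cc1` is not yet measured. It differs from compound 2 only at the sulfonyl sulfur: 2-chloro-6-methoxy-4-methylphenyl in place of 2-(trifluoromethoxy)phenyl on a sulfonyl sulfur. Among the compounds with values here, the one measured step that bears on this, the exchange of one aryl group for another at the same place, was a number 1 percentage points lower from compound 1 to compound 2 (within the scatter), so no step beyond the scatter is expected here either: no change at the digits printed from compound 2 to compound 3 (within the scatter). For compound 3 the expected value is 23%, with a range from 8% to 40%.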

Compound 3, a percentage reported as inhibition, at one concentration (the size of the read-out at that concentration, not a potency): 12%
Compound 3: the middle estimate sits 11 percentage points above what was measured; the measured number falls inside the stated range.
By their numbers in this assay, from the lowest: compound 3; then compounds 2 and 1 (each within the scatter of the next).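

Exchanging the aryl group on the sulfonyl sulfur can shift the number in this assay after all: 2-chloro-6-methoxy-4-methylphenyl gives a lower reading than either earlier group (a number 11 percentage points lower from compound 2 to compound 3 (beyond the scatter); a number 12 percentage points lower from compound 1 to compound 3 (beyond the scatter)). This place therefore responds to the choice of aryl group, though among these compounds the only shift beyond the scatter is a modest drop. No supporting measurement bears on what lies behind that drop. From the compounds shown here alone, it remains open which of the chloro, methoxy and methyl groups on that ring matters. Also open, going by these compounds, is whether an aryl ring carrying an amine or a carboxylic acid would raise the number.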